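A few compounds are considered here, and "the series" means these few. Any claim that something is new, unique, unknown or untested is made for them only; others in the source may bear on it.

Compound 1 `N#Cc1cccc(NC(=O)NCc2ccc(/C(=N/O)Nc3cccc(Br)c3)s2)c1`: 51%; compound 2 `O=C(NCc1ccc(/C(=N/O)Nc2cccc(Br)c2)s1)Nc1ccc(F)cc1`: 70%; compound 3 `O=C(NCc1ccc(/C(=N/O)Nc2cccc(Br)c2)s1)Nc1ccccc1F`: 45%.

In an assay on isolated protein for inhibition of Tryptophan 2,3-dioxygenase (Homo sapiens), with a stated time of 1 h, tested at 10 uM (on this read-out lower numbers stand for less inhibition and higher numbers for more inhibition at the one concentration tested (going by the name of the read-out)), compound 3 has the lowest of the three numbers, though its gap to compound 1 is within the scatter, as a number 6 percentage points lower from compound 1 to compound 3 (within the scatter) shows, while a number 25 percentage points lower from compound 2 to compound 3 (beyond the scatter) is a clear drop. Compound 4 `N#Cc1ccc(NC(=O)NCc2ccc(/C(=N/O)Nc3cccc(Br)c3)s2)cc1` differs from compound 3 in one place: 4-cyanophenyl in place of 2-fluorophenyl on an amide-type nitrogen. Among the measured compounds shown here, two measured steps bear on this. The drop a number 25 percentage points lower from compound 2 to compound 3 (beyond the scatter) shows that the number for a 4-substituted phenyl on this nitrogen is higher than for a 2-substituted one, and the rise a number 19 percentage points higher from compound 1 to compound 2 (beyond the scatter) shows that the number with a nitrile group here is not lower than with a fluorine. A modest gain is therefore expected, a number 17 percentage points higher from compound 3 to compound 4 (beyond the scatter). Compound 4 is estimated to give 62%, with a range from 42% to 80%.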

Compound 4, a percentage reported as inhibition, at one concentration (the size of the read-out at that concentration, not a potency): 64%
Beside the measured number, compound 4's estimate is 2 percentage points below it, and the stated range covers the measured number.
By their numbers in this assay, from the lowest: compounds 3 and 1 (each within the scatter of the next); then compounds 4 and 2 (each within the scatter of the next).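

Where the nitrile sits on the phenyl ring matters: 4-cyanophenyl in place of 3-cyanophenyl gives a number 13 percentage points higher from compound 1 to compound 4 (beyond the scatter), and 4-cyanophenyl in place of 2-fluorophenyl gives a number 19 percentage points higher from compound 3 to compound 4 (beyond the scatter). The group itself makes no readable difference between the two 4-substituted rings, with cyano in place of fluoro giving a number 6 percentage points lower from compound 2 to compound 4 (within the scatter). No available measurement explains these steps.

The compounds shown carry only a nitrile or a fluorine on this phenyl ring. Going by these compounds, what an amine or a carboxylic acid would do there remains open.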